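This account rests on a few compounds, and the source may have more. Where it says the series, first, only, none or still open, it means among the compounds named here.

Compound 3 `COc1cc(OC)c(-c2coc3cc(OCc4ccc(Br)cc4)ccc3c2=O)cc1OC` gives 1000 nM in a functional assay on A-375 cells (Homo sapiens) for antiproliferative activity, read by MTT assay, with a stated time of 24 h (on this read-out higher numbers stand for weaker inhibition and lower numbers for stronger inhibition), the lowest of the three numbers shown. Compound 2 `COc1cc(OC)c(-c2coc3cc(OCc4ccc(F)cc4)ccc3c2=O)cc1OC`, at 1720 nM, lies closest, and the step of a 1.7-fold lower number from compound 2 to compound 3 (0.24 log units; within the scatter) sits within the scatter, so the two cannot be told apart. Compound 1 `C#CCOc1ccc2c(=O)c(-c3cc(OC)c(OC)cc3OC)coc2c1` gives 3680 nM. The steps of a 3.7-fold lower number from compound 1 to compound 3 (0.57 log units; beyond the scatter) and a 2.1-fold lower number from compound 1 to compound 2 (0.33 log units; beyond the scatter) both lie beyond the scatter. Compound 4 `COc1cc(OC)c(-c2coc3cc(OCc4ccc(Cl)cc4)ccc3c2=O)cc1OC` differs from compound 3 in one substituent: chloro in place of bromo on an aromatic carbon. Within the data shown here, the only measured step that bears on this kind of change is the exchange of fluoro for bromo, a 1.7-fold lower number from compound 2 to compound 3 (0.24 log units; within the scatter), which stayed within the scatter; the replacement of ethynyl by 4-bromophenyl or 4-fluorophenyl, a 3.7-fold lower number from compound 1 to compound 3 (0.57 log units; beyond the scatter) and a 2.1-fold lower number from compound 1 to compound 2 (0.33 log units; beyond the scatter), alters a different part of the molecule and says nothing about a chloro-for-bromo swap. Since one such exchange produced no step beyond the scatter, none is expected here either, and a chloro compound is estimated to land close to the fluoro and bromo pair. Compound 4 is therefore expected to give 1300 nM, within 600 nM to 2800 nM, which corresponds to an expected step of a 1.3-fold higher number from compound 3 to compound 4 (0.11 log units; within the scatter).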

Compound 4, half-maximal inhibitory concentration: 1020 nM
For compound 4 the middle estimate is 1.3-fold (0.11 log units) above the measured one; low and high end bracket the measured number.
By their numbers in this assay, from the lowest: compounds 3, 4 and 2 (each within the scatter of the next); then compound 1.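

In this assay the chloro compound completes a set of three halogens on this aromatic carbon, and both a 1.0-fold higher number from compound 3 to compound 4 (0.01 log units; within the scatter) and a 1.7-fold lower number from compound 2 to compound 4 (0.23 log units; within the scatter) stay within the scatter, so fluoro, bromo and chloro cannot be told apart here. The swap of bromo for chloro thus leaves the number in place, and the halogen's identity shows no effect across these three compounds. The step of a 3.6-fold lower number from compound 1 to compound 4 (0.56 log units; beyond the scatter) lies beyond the scatter, so all three halogen-bearing compounds now stand apart from the ethynyl compound 1, with none among them going against this. Nothing at hand gives a reason for these results.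

The compounds shown leave open whether the halogen is needed at all, since a plain benzyl group carrying only hydrogen at this carbon does not appear among them. They also leave open how a methoxy, a nitrile or an amine would read at the same carbon.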